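The source may hold more compounds than are shown below. What is called first, only, known or untested is meant among the compounds shown, and "the series" means these compounds.

Measured compounds:
- compound 1, `COc1ccc(NC(=O)CCCCCCCSc2nnc(Cc3nn(C)c(=O)c4ccccc34)n2C)cc1`, in an assay on isolated protein (Mus musculus) for inhibition of IL15-IL15 receptor (Homo sapiens), read by resazurin assay, with stated times of 30 min and 2.5 days (on this read-out higher numbers stand for weaker inhibition and lower numbers for stronger inhibition), compound 1 gives 3900 nM
- compound 2, `Cn1c(Cc2nn(C)c(=O)c3ccccc23)nnc1SCCCCCC(=O)Nc1ccc(Cl)cc1Cl`, in this assay compound 2 gives 4100 nM

These two numbers sit within the usual scatter of each other, so compound 1 cannot be told apart from compound 2 on this read-out: the shared core and the long sulfur-linked chain ending in an aryl amide give much the same result whether that aryl group carries a methoxy group or two chlorines.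

Compound 3, `Cn1c(Cc2nn(C)c(=O)c3ccccc23)nnc1SCCCCCCCC(=O)Oc1ccc(Cl)cc1Cl`, has not yet been measured. It differs from compound 1 by 2,4-dichlorophenoxy in place of (4-methoxyphenyl)amino on a carbonyl carbon. Among the compounds with values here, the amide linking the chain to the aromatic ring thus becomes an ester, and the aromatic ring is the one already present in compound 2. Since compound 2 shows that the dichlorophenyl ring on its own changes little, the open question is the loss of the amide hydrogen. Within the data shown here, with no measured pair that isolates that change, the step is expected to be small, at most a modest weakening: the estimated step from compound 1 to compound 3 in this assay is a 1.4-fold higher number from compound 1 to compound 3 (0.15 log units; within the scatter). Compound 3 is therefore estimated at 5500 nM, with a range from 1800 nM to 17000 nM.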

Compound 3, half-maximal inhibitory concentration: 800 nM
For compound 3 the middle estimate is 6.9-fold (0.84 log units) above the measured one, outside the stated range (below it).
By their numbers in this assay, from the lowest: compound 3; then compounds 1 and 2 (each within the scatter of the next).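

At the carbonyl carbon at the end of the chain, the swap of (4-methoxyphenyl)amino for 2,4-dichlorophenoxy produces a change in this assay that goes beyond the usual scatter: a 4.9-fold lower number from compound 1 to compound 3 (0.69 log units; beyond the scatter). A lower number here means stronger inhibition, so this position does respond to what is attached to it, and the amide hydrogen is not required for inhibition at this level, since compound 3 has no such hydrogen and still gives the lower number. The swap changes the linking atom and the groups on the aromatic ring in a single step, and no further measurement is available to explain the result.

The compounds shown leave open how much of the step belongs to the ester link and how much to the two chlorines; a 4-methoxyphenyl ester or a 2,4-dichlorophenyl amide on this same chain would separate the two. A free carboxylic acid at this carbonyl carbon would also test whether the aromatic ring is needed at all.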